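Tolerance at the assay limit: from nitrile to trifluoromethyl

The compounds below may be only part of what the source reports. "The series", "measured", "known", "first", "only" and "open" are said of these compounds alone.

Measured in a functional assay on HEK293 cells (Homo sapiens) for cytotoxicity; a higher number here means that more compound is tolerated, a lower number that less compound is tolerated:
Compound 1 `COc1ccc([C@H]2CC(=O)N(c3cccc(N(C)C)c3)C2)cc1OC1CCCC1`: > 10000 nM (a limit)
Compound 2 `COc1ccc([C@H]2CC(=O)N(c3cccc(C#N)c3)C2)cc1OC1CCCC1`: > 10000 nM (a limit)

Neither entry is an exact number. As far as these compounds go, compound 2 sits at the limit of > 10000 nM in this assay, at which 2 of the 2 values shown sit, so its true value is unknown. The next structure is compound 3 `COc1ccc([C@H]2CC(=O)N(c3ccc(C(F)(F)F)cc3)C2)cc1OC1CCCC1`, and the change is 4-(trifluoromethyl)phenyl in place of 3-cyanophenyl on an amide-type nitrogen in a ring. Here 4-(trifluoromethyl)phenyl replaces 3-cyanophenyl on an amide-type nitrogen in a ring.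

Going by the values given here, the only measured step is a step that the two limits leave unreadable from compound 1 to compound 2. It offers no size to carry over, so no clear direction can be expected in this assay. Another reading at the limit is the likeliest outcome. The estimated change is a step that the limit leaves unreadable from compound 2 to compound 3, and this expectation rests on very little data. Compound 3 is expected at about 15000 nM, with an estimated range from 5000 nM to 40000 nM.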

Compound 3, half-maximal cytotoxic concentration: > 10000 nM
Compound 3: only a limit was reported; the forecaster's own chance of this, stated with the estimate: 85%; the middle value lies beyond the limit too.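

Compound 3, like compound 1 and compound 2, gives only a limit, so no step among these three compounds can be read: the limit of > 10000 nM in this assay, at which 3 of the 3 values shown sit.

The compounds shown leave open how much of each compound is tolerated, and whether 4-(trifluoromethyl)phenyl in place of 3-cyanophenyl changes that tolerance at all.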